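The source may report more compounds than this note shows. Statements on the series, on what has been measured and on what is new or still open speak of the compounds shown alone.

In an ADME assay on MT4 cells (Homo sapiens) for cytotoxicity, read by MTT assay (on this read-out lower numbers stand for higher toxicity in this test and higher numbers for lower toxicity in this test), compound 1 (`Cc1c(Cc2c(F)cccc2F)nc(SCc2ccccn2)[nH]c1=O`) gives > 70000 nM as a limit of the assay and not a number. Compound 2 (`CC(C)Sc1nc(Cc2c(F)cccc2F)cc(=O)[nH]1`) likewise gives > 84000 nM as a limit. Compound 3 (`O=C(CSc1nc(Cc2c(Cl)cccc2Cl)cc(=O)[nH]1)c1ccc(F)cc1`) gives > 59000 nM as a limit too. All three readings are therefore limits, so compound 1 has no exact place among them, and no measured step connects any two of these compounds.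

The account now turns to compound 4 (`Cc1c(Cc2c(F)cccc2F)nc(SCC(=O)c2ccc(F)cc2)[nH]c1=O`), which keeps the core of compound 1 and alters only the group on the side chain ((4-fluorophenyl)carbonyl in place of pyridin-2-yl on a saturated chain carbon bound to a sulfur), with (4-fluorophenyl)carbonyl in place of pyridin-2-yl on a saturated chain carbon bound to a sulfur. Compound 3 carries that same group at that kind of place, and its reading is the limit > 59000 nM on a core of its own. No step beyond the usual scatter is therefore expected in this assay and the estimated change is an at least 1.2-fold lower number from compound 1 to compound 4 (0.10 log units; that floor lies within the scatter) in size. For compound 4 the expected value is 55000 nM with an estimated range from 18000 nM to 100000 nM and the assay may well report only a limit again.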

Compound 4, half-maximal cytotoxic concentration: > 62000 nM
Compound 4 ended at the assay's limit; the forecaster's own chance of this, stated with the estimate: 70%; middle value at least 1.1-fold (0.05 log units) away from the limit.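

In this assay compound 4 gives > 62000 nM, a limit and not a number. Compound 1 also stands only at a limit, so no step can be read between compound 1 and compound 4. The compounds shown leave open where any of the four would reach a half-maximal cytotoxic concentration, and how they rank.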